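Working notes: from compound 2 to compound 3

The source may hold more compounds than are shown below. What is called first, only, known or untested is meant among the compounds shown, and "the series" means these compounds.

Measured so far:
compound 1, `COc1cc(-c2nn(-c3cccc(NC(=O)c4ccc(Cl)c(C(F)(F)F)c4)c3)cc2-c2ccncc2)ccc1Cl`: > 32500 nM (a limit)
compound 2, `COc1cc(-c2nn(-c3cccc(NC(=O)Nc4ccc(Cl)c(C(F)(F)F)c4)c3)cc2-c2ccncc2)ccc1Cl`: > 32500 nM (a limit)

In a functional assay on PC-3 cells (Homo sapiens) for inhibition, read by sulforhodamine B assay, with a stated time of 48 h (a higher number here means that more compound is tolerated, a lower number that less compound is tolerated), compound 1 gives > 32500 nM, which is a limit of the assay and not a number. Compound 2 gives > 32500 nM in this assay, again a limit. Within the data shown here, the one step between them, a step that the two limits leave unreadable from compound 1 to compound 2, therefore cannot be read. Compound 2 stands where every value shown stands: the limit of > 32500 nM in this assay, at which 2 of the 2 values shown sit.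

Compound 3, `COc1cc(-c2nn(-c3cccc(NC(=O)c4ccccc4)c3)cc2-c2ccncc2)ccc1Cl`, is not yet measured. Its change from compound 2 is phenyl in place of (4-chloro-3-(trifluoromethyl)phenyl)amino on a carbonyl carbon. Among the measured compounds shown here, the only measured step that touches this position is a step that the two limits leave unreadable from compound 1 to compound 2, and it gives no size and no direction, so nothing measured sets a scale for the new step.

The expectation rests on the position of compound 2 alone, because compound 2 sits at > 32500 nM in this assay. The step from compound 2 to compound 3 is expected to be a number no higher from compound 2 to compound 3 (the limit leaves the size open). For compound 3 in this assay the estimate is 32500 nM, with a range from 10000 nM to 80000 nM, most likely reported again only as a limit.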

Compound 3, concentration lethal to 50% of the cells: > 100000 nM
Compound 3 ended at the assay's limit (the forecaster's own chance of this, stated with the estimate: 70%); at least 3.0-fold (0.48 log units) between middle value and limit.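

In this assay compound 3 gives > 100000 nM, a limit of the assay and not a number. Among these compounds, compound 1 and compound 2 also stand at limits, so no step among compound 1, compound 2 and compound 3 can be read. The compounds shown leave open whether any of the three groups on the carbonyl carbon changes the value in this assay.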